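The compounds below may be only part of what the source reports. "The series", "measured", "known", "first", "only" and "open" are said of these compounds alone.

Measured set in a functional assay (strain AB) with Danio rerio as the target, read by microscopy, with a stated time of 1 h; a lower number here means that less compound is needed, a higher number that more compound is needed for the effect:
compound 1 `CCN1CCc2c(sc(NC(=O)Nc3ccc(Br)cc3)c2C(N)=O)C1`: 3130 nM
compound 2 `CCN1CCc2c(sc(NC(=O)Nc3ccc(Cl)cc3)c2C(N)=O)C1`: 3120 nM
compound 3 `CCN1CCc2c(sc(NC(=O)Nc3ccc(Cl)cc3)c2C(=O)c2nnco2)C1`: a limit, > 25000 nM

Compound 2 holds the lowest of the two numbers given, with compound 1 next to it at a 1.0-fold lower number from compound 1 to compound 2 (0.00 log units; within the scatter), so the pair cannot be told apart. Within the data shown here, compound 3 returns only a limit of this assay, and the step of an at least 8.0-fold higher number from compound 2 to compound 3 (0.90 log units; beyond the scatter) is the one clear change seen so far; the reason is not traced beyond the note (the limit of > 25000 nM in this assay, at which 1 of the 3 values shown sits).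

Compound 4 `NC(=O)c1c(NC(=O)Nc2ccc(Cl)cc2)sc2c1CCN(CC1CCCC1)C2` is the next case. The change from compound 2 is cyclopentyl in place of methyl on a saturated chain carbon bound to an amine nitrogen in a ring. Among the measured compounds shown here, neither measured step touches this site: the halogen swap sits on the aryl ring and the oxadiazole replacement sits on the carbonyl carbon, so no precedent for the ring amine substituent exists here. With the amide and the chloroaryl urea of compound 2 kept, the step of a 1.0-fold lower number from compound 2 to compound 4 (0.02 log units; within the scatter) is expected to stay within the scatter. Compound 4 is therefore estimated at 3000 nM, with a range from 1000 nM to 10000 nM.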

Compound 4, half-maximal effective concentration: 1830 nM
Beside the measured number, compound 4's estimate is 1.6-fold (0.21 log units) above it; the range from low to high includes it.
By their numbers in this assay, from the lowest: compounds 4, 2 and 1 (each within the scatter of the next). At a limit, above all of these: compound 3.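

In this assay, the swap at the saturated chain carbon bound to the ring amine nitrogen puts a cyclopentyl group of five heavy atoms in place of a methyl of one, and the result is a 1.7-fold lower number from compound 2 to compound 4 (0.23 log units; within the scatter). This site therefore accepts a carbon-only five-membered ring with no change that can be told from the scatter, which neither the halogen swap nor the oxadiazole replacement could show. Nothing measured here bears on a cause for this outcome.

Open, from the compounds shown here alone, is whether a phenyl ring, a longer straight chain or a carboxylic acid at this site would stay in the same range. Also open, going by these compounds, is whether the cyclopentyl group gives the same reading with the bromo aryl urea of compound 1.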